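Halogen swap on the aryl urea of compound 1

The source may hold more compounds than are shown below. What is called first, only, known or untested is meant among the compounds shown, and "the series" means these compounds.

Measured so far:
compound 1 `O=C(Nc1cccc(CNc2nccnc2Cl)c1)Nc1ccc(F)c(Cl)c1` — 5020 nM
compound 2 `CS(=O)(=O)c1ccc(NC(=O)Nc2cccc(CNc3nccnc3Cl)c2)cc1` — 12300 nM

In a functional assay on MGC-803 cells (Homo sapiens) for antiproliferative activity, read by MTT assay, with a stated time of 48 h (on this read-out higher numbers stand for weaker inhibition and lower numbers for stronger inhibition), compound 1 gives the lower of the two numbers, and compound 2 lies beyond the scatter above it. Compound 3 `O=C(Nc1cccc(CNc2nccnc2Cl)c1)Nc1ccc(Cl)c(Cl)c1` differs from compound 1 only by chloro in place of fluoro on an aromatic carbon, the 3-chloro-4-fluorophenyl of compound 1 becoming 3,4-dichlorophenyl. For the measured compounds named here, no measured pair shows this change, so its size is unknown. The expected step in this assay is small, within the scatter, if anything toward a lower number: a 1.4-fold lower number from compound 1 to compound 3 (0.16 log units; within the scatter). Compound 3 is estimated at 3500 nM, with a range from 1200 nM to 10000 nM.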

Compound 3, half-maximal inhibitory concentration: 4970 nM
For compound 3 the middle estimate is 1.4-fold (0.15 log units) below the measured one, within the range that was stated.
By their numbers in this assay, from the lowest: compounds 3 and 1 (each within the scatter of the next); then compound 2.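

In this assay, chloro in place of fluoro on this aromatic carbon, ortho to a chloro group and para to a large group, gives a 1.0-fold lower number from compound 1 to compound 3 (0.00 log units; within the scatter). For the compounds shown here, this is the only measured pair for this change, and it shows that the 3-chloro-4-fluorophenyl and 3,4-dichlorophenyl ureas cannot be told apart on this read-out. Nothing measured bears on the reason for this result.

Still open, on these data alone, is whether a bromo, a methoxy or an amine at this place would shift the number beyond the scatter. As far as these compounds go, the effect of removing the halogen from this carbon also remains open.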